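Methoxy-to-hydrogen step toward compound 4: working notes

The source may hold more compounds than are shown below. What is called first, only, known or untested is meant among the compounds shown, and "the series" means these compounds.

Three compounds of this series have numbers in a functional assay on SK-MEL-28 cells (Homo sapiens) for cytotoxicity, read by sulforhodamine B assay, with a stated time of 48 h, tested at 10 uM; a higher number here means a weaker effect of the compound at the concentration tested, a lower number a stronger effect. Compound 1 `COc1ccc(-c2cc(/C=C/C(=O)c3ccc(N)cc3)[nH]n2)cc1` gives -60%. Compound 2 `COc1ccc(-c2cc(/C=C/C(=O)c3ccc(N)cc3)[nH]n2)cc1OC` gives -29%. Compound 3 `COc1cc(C(=O)/C=C/c2cc(-c3cc(OC)c(OC)c(OC)c3)n[nH]2)cc(OC)c1OC` gives -92%, the lowest of the three, with compound 1 nearest and compound 2 furthest, both gaps beyond the scatter.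

Compounds 2 and 1 differ in one place: hydrogen in place of methoxy on an aromatic carbon. This change made a step of a number 31 percentage points lower from compound 2 to compound 1 (beyond the scatter). How the core of compound 3 differs from that of compound 2 is not broken down here.

Compound 4 `COc1ccc(-c2cc(/C=C/C(=O)c3cc(OC)c(OC)c(OC)c3)[nH]n2)cc1OC` has not been measured in this assay. It differs from compound 3 by hydrogen in place of methoxy on an aromatic carbon. The surroundings are not identical to those of the step from compound 2 to compound 1: in compound 4 the carbon is also meta to a methoxy group, which the earlier place does not show, so this is the same kind of change rather than the same change.

For compound 4 a step of a number 3 percentage points lower from compound 3 to compound 4 (within the scatter) is expected in this assay, smaller than the earlier one, because compound 3 already gives -92% and the read-out leaves little room for a further lowering of the same size as the step from compound 2 to compound 1. Compound 4 is therefore estimated at -95%, with an expected range from -105% to -75%.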

Compound 4, a percentage reported as activity, at one concentration (the size of the read-out at that concentration, not a potency): -49%
Compound 4: the middle estimate sits 46 percentage points below what was measured; measured number above the stated range.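

In this assay, hydrogen in place of methoxy on an aromatic carbon gives a number 43 percentage points higher from compound 3 to compound 4 (beyond the scatter), so on the core of compound 3 the loss of this methoxy group goes with a weaker effect at the concentration tested. Set beside the earlier step, the same change does not carry from one core to the other, neither in size nor in direction: the same change on two cores in this assay, a number 31 percentage points lower (beyond the scatter) from compound 2 to compound 1 and a number 43 percentage points higher (beyond the scatter) from compound 3 to compound 4, 74 percentage points apart, beyond the scatter of two such steps What the two steps do not show is which difference between the cores sets the direction: the place in compound 4 is also meta to a methoxy group, which the earlier place does not show, but the cores differ in other ways too, and one pair on each core cannot separate these, so the result says only that a step read on one core is no guide to the other in this series.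

The compounds shown hold only methoxy or hydrogen at these places, which leaves open how a fluorine atom, a hydroxyl group or an ethoxy group would read on each core. Also open, on these data alone, is whether the opposite directions persist on further cores, since the comparison rests on two pairs alone.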